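This account rests on a few compounds, and the source may have more. Where it says the series, first, only, none or still open, it means among the compounds named here.

Three compounds share one core and differ only in a single group on an aromatic ring. Compound 1 `CCOC(=O)CCCCCOc1cccc(CN(C(=O)c2ccc(-c3cccc(N(C)C)c3)cc2)C(C)C)c1` carries dimethylamino there, compound 2 `CCOC(=O)CCCCCOc1cccc(CN(C(=O)c2ccc(-c3cccc(NC(C)=O)c3)cc2)C(C)C)c1` acetamido, and compound 3 `CCOC(=O)CCCCCOc1cccc(CN(C(=O)c2ccc(-c3cccc(OCC(C)C)c3)cc2)C(C)C)c1` isobutoxy. In an ADME assay on HepG2 cells (Homo sapiens) for cytotoxicity, read by CellTiter-Glo and resazurin assay, with a stated time of 72 h (a lower number here means that less compound is needed, a higher number that more compound is needed for the effect), compound 1 gives > 26000 nM, which is a limit of the assay rather than a number. Compound 2 gives > 26000 nM in this assay, again a limit. Compound 3 likewise gives > 26000 nM in this assay, also a limit. Because all three sit at the limit of > 26000 nM in this assay, at which 3 of the 3 values shown sit, the steps a step that the two limits leave unreadable from compound 1 to compound 2, a step that the two limits leave unreadable from compound 1 to compound 3 and a step that the two limits leave unreadable from compound 2 to compound 3 cannot be read in size; compound 3 thus stands at the same limit as the other two, with nothing to set it apart. Compound 4 `CCOC(=O)CCCCCOc1cccc(CN(C(=O)c2ccc(-c3cccc(Oc4ccccc4)c3)cc2)C(C)C)c1` differs from compound 3 by phenyl in place of isobutyl on an oxygen on an aromatic ring. Going by the values given here, no measured step covers this exchange, and the three steps that exist tell only that three different groups at this place all left the values at the limit. The expected step that the limit leaves unreadable from compound 3 to compound 4 is therefore none beyond the scatter. Compound 4 is estimated at 30000 nM in this assay, with a range from 12000 nM to 80000 nM, and most likely the assay will again report only a limit.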

Compound 4, half-maximal effective concentration: > 26000 nM
Compound 4: no number, only a limit; the forecaster's own chance of this, stated with the estimate: 80%; the middle value does not contradict the limit.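

In this assay compound 4 gives > 26000 nM, which is again a limit and not a number. The steps linking compound 4 to compound 1, compound 2 and compound 3 cannot be read in size, because all four share one limit: the limit of > 26000 nM in this assay, at which 4 of the 4 values shown sit.

On these data alone, what stays open is how much of any of these four compounds is needed for the effect, and whether the groups exchanged here differ at all.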